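Chloro in Place of Bromo: a Small Halogen Exchange

The compounds below may be only part of what the source reports. "The series", "measured", "known", "first", "only" and "open" are said of these compounds alone.

Within the data shown here, in a functional assay on MCF7 cells (Homo sapiens) for inhibition, read by MTT assay, with a stated time of 72 h (on this read-out higher numbers stand for weaker inhibition of growth and lower numbers for stronger inhibition of growth), compound 2 `O=S(=O)(NCCCNCc1ccc(Br)cc1)c1cc(C(F)(F)F)cc(C(F)(F)F)c1` gives 1900 nM, the lowest of the two numbers so far, while compound 1 `O=S(=O)(NCCCNCc1ccc(Cl)c(C(F)(F)F)c1)c1cc(C(F)(F)F)cc(C(F)(F)F)c1` gives 3500 nM, the step of a 1.8-fold lower number from compound 1 to compound 2 (0.27 log units; within the scatter) lying within the scatter. Compound 3 `O=S(=O)(NCCCNCc1ccc(Cl)cc1)c1cc(C(F)(F)F)cc(C(F)(F)F)c1` differs from compound 2 by chloro in place of bromo on an aromatic carbon. Among the measured compounds shown here, the only measured step bears on this change just loosely, since it exchanged the whole aryl group and yet stayed within the scatter; a single halogen exchange counts far less. One therefore expects no step beyond the scatter in this assay. Compound 3 is estimated at 2200 nM, between 1000 nM and 5000 nM, with an expected step of a 1.2-fold higher number from compound 2 to compound 3 (0.06 log units; within the scatter).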

Compound 3, concentration for 50% growth inhibition: 2400 nM
For compound 3 the middle estimate is 1.1-fold (0.04 log units) below the measured one, within the range that was stated.
By their numbers in this assay, from the lowest: compounds 2, 3 and 1 (each within the scatter of the next).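

Chloro in place of bromo on this aromatic carbon gives a 1.3-fold higher number from compound 2 to compound 3 (0.10 log units; within the scatter) in this assay, so the two halogens cannot be told apart at this position. Hydrogen in place of trifluoromethyl on an aromatic carbon, now seen as a single change, gives a 1.5-fold lower number from compound 1 to compound 3 (0.16 log units; within the scatter) and also stays within the scatter. No supporting evidence is available that would account for these steps.

As far as these compounds go, whether a different group on this carbon, such as methoxy, an amine or a carboxylic acid, would give a step beyond the scatter remains open. The same holds for a longer chain.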